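Thioureas and selenoureas on two acyl cores: growth inhibition

The source may report more compounds than this note shows. Statements on the series, on what has been measured and on what is new or still open speak of the compounds shown alone.

Compound 1 `CS/C(=N\C(=O)c1csc([N+](=O)[O-])c1)NC(=O)c1csc([N+](=O)[O-])c1` carries a methylsulfanyl group on the carbon with a double bond to nitrogen, flanked on both sides by the same acyl arm. In a functional assay on PC-3 cells (Homo sapiens) for cytotoxicity, read by MTT assay, with a stated time of 72 h (on this read-out higher numbers stand for weaker inhibition of growth and lower numbers for stronger inhibition of growth), compound 1 gives 41500 nM. Compound 2 `O=C(/N=C(/NC(=O)c1csc([N+](=O)[O-])c1)[Se]Cc1ccccc1)c1csc([N+](=O)[O-])c1` differs by a group of 8 heavy atoms (7 carbon, 1 selenium; one six-membered aromatic ring of carbon only) in place of a group of 2 heavy atoms (1 carbon, 1 sulfur; no ring), on a carbon with a double bond to nitrogen. In this assay compound 2 gives 35900 nM, and the step is a 1.2-fold lower number from compound 1 to compound 2 (0.06 log units; within the scatter).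

Compound 3 `CS/C(=N\C(=O)c1cnc2ccccc2c1)NC(=O)c1cnc2ccccc2c1` keeps the methylsulfanyl group but carries different acyl arms; the difference between the core of compound 1 and the core of compound 3 is not broken down here. In this assay compound 3 gives 76300 nM. Against compound 2 the gap is beyond the scatter; against compound 1 it is within the scatter, so no order is read between those two.

Compound 4 `O=C(/N=C(/NC(=O)c1cnc2ccccc2c1)[Se]Cc1ccccc1)c1cnc2ccccc2c1` stands to compound 3 as compound 2 stands to compound 1: the change is a group of 8 heavy atoms (7 carbon, 1 selenium; one six-membered aromatic ring of carbon only) in place of a group of 2 heavy atoms (1 carbon, 1 sulfur; no ring), on a carbon with a double bond to nitrogen, and the surroundings of the place are the same, so it is the same change, seen once before among these compounds. The expectation rests on that single prior case, where the step was a 1.2-fold lower number from compound 1 to compound 2 (0.06 log units; within the scatter) and stayed within the scatter. The step from compound 3 to compound 4 is therefore expected to be a 1.2-fold lower number from compound 3 to compound 4 (0.06 log units; within the scatter). In this assay compound 4 is estimated at 66000 nM, with a range expected from 30000 nM to 145000 nM.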

Compound 4, concentration for 50% growth inhibition: 34800 nM
The estimate for compound 4 lay 1.9-fold (0.28 log units) above the measured number; the range from low to high includes it.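

On the core of compound 3, putting the group of 8 heavy atoms, with its selenium and its six-membered aromatic ring, in place of methylsulfanyl on the carbon with a double bond to nitrogen gives, in this assay, a 2.2-fold lower number from compound 3 to compound 4 (0.34 log units; beyond the scatter). This step alone lies beyond the scatter, but it is modest, and no difference in the size of the change is read between the core of compound 1 and the core of compound 3. As far as these two pairs go, the change carries from one core to the other without a measurable dependence on the core, though two pairs make no rule for other cores and do not establish a step of any fixed size, as the comparison shows: the same change on two cores in this assay, a 1.2-fold lower number (0.06 log units; within the scatter) from compound 1 to compound 2 and a 2.2-fold lower number (0.34 log units; beyond the scatter) from compound 3 to compound 4, 1.9-fold (0.28 log units) apart, within the scatter of two such steps.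

The change swaps the sulfur for selenium and adds the aromatic ring in one move, so the compounds shown leave open how much of the step belongs to each; a benzylsulfanyl group or a methylselanyl group at the same place would separate the two. Also open, going by these compounds, is how a longer alkyl chain on the selenium, or an amine at that carbon, would behave on either core.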